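Aryl urea series: nitro to fluoro step from compound 2

The source may hold more compounds than are shown below. What is called first, only, known or untested is meant among the compounds shown, and "the series" means these compounds.

Measured so far in a functional assay on CRL2813 cells (Homo sapiens) for cytotoxicity, read by sulforhodamine B assay, with a stated time of 5 days; a lower number here means a stronger inhibitor, a higher number a weaker inhibitor:
- compound 1, `O=C(Nc1cccc(C(F)(F)F)c1)N[C@H]1CC[C@H](O)CC1`: > 20000 nM, a limit of the assay
- compound 2, `O=C(Nc1ccccc1[N+](=O)[O-])N[C@H]1CC[C@H](Oc2ccc(F)cc2)CC1`: 3500 nM
- compound 3, `COc1ccccc1NC(=O)N[C@H]1CC[C@H](Oc2ccc(F)cc2)CC1`: > 20000 nM, a limit of the assay

Going by the values given here, compound 2 holds the only measured number in this assay; the other two values are limits. Among the compounds with values here, one measured step bears on the change at hand: an at least 5.7-fold higher number from compound 2 to compound 3 (0.75 log units; beyond the scatter), which runs into (the limit of > 20000 nM in this assay, at which 2 of the 3 values shown sit). Compound 4, `O=C(Nc1ccccc1F)N[C@H]1CC[C@H](Oc2ccc(F)cc2)CC1`, differs from compound 2 by fluoro in place of nitro on an aromatic carbon. Given the step from compound 2 to compound 3, a weakening of similar order is expected here too, with a real chance that compound 4 also returns only a limit. Compound 4 is estimated at 12000 nM (range 4000 nM to 30000 nM), meaning an expected step of a 3.4-fold higher number from compound 2 to compound 4 (0.54 log units; beyond the scatter).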

Compound 4, half-maximal inhibitory concentration: 17500 nM
For compound 4 the middle estimate is 1.5-fold (0.16 log units) below the measured one; measured number inside the range.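

Fluoro in place of nitro at this place on the aromatic ring gives a 5.0-fold higher number from compound 2 to compound 4 (0.70 log units; beyond the scatter) in this assay, so methoxy is no longer the only replacement that loses ground against nitro. The fluoro compound gives a measured number rather than a limit, but the comparison with methoxy reads an at least 1.1-fold lower number from compound 3 to compound 4 (0.05 log units; that floor lies within the scatter), so these two replacements cannot be ordered. The comparison stops at the ceiling: the limit of > 20000 nM in this assay, at which 2 of the 4 values shown sit.

Still open, going by these compounds, is how an amine or a nitrile at this same place would read against nitro. On these data alone, whether the nitro advantage holds with a different group on the far side of the core also remains open.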